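A few compounds are considered here, and "the series" means these few. Any claim that something is new, unique, unknown or untested is made for them only; others in the source may bear on it.

Compound 1 `COc1ccc2cc(C(C)c3nnc4n3N=C(c3ccc([N+](=O)[O-])cc3)CS4)ccc2c1` gives 15100 nM in a functional assay on HCT-116 cells (Homo sapiens) for inhibition, read by sulforhodamine B assay, with a stated time of 72 h; on this read-out higher numbers stand for weaker inhibition and lower numbers for stronger inhibition.
Compound 2 `CC(C)Cc1ccc(C(C)c2nnc3n2N=C(c2ccc(F)cc2)CS3)cc1` gives 12400 nM in this assay.

Compound 2 holds the lower of the two numbers, yet compound 1 sits within the scatter of it, so the two cannot be set apart. Compound 3 `COc1ccc(C2=Nn3c(nnc3C(C)c3ccc(CC(C)C)cc3)SC2)cc1` keeps the shared core of compound 2 and changes one spot: methoxy in place of fluoro on an aromatic carbon. For the measured compounds named here, no measured pair shows this exchange, so its effect in this assay is unknown. For compound 3 a step no larger than the scatter is expected, in either direction: a 1.1-fold higher number from compound 2 to compound 3 (0.05 log units; within the scatter). Compound 3 is therefore estimated at 14000 nM, with a range from 5000 nM to 40000 nM.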

Compound 3, half-maximal inhibitory concentration: 4200 nM
Estimate against measurement, compound 3: 3.3-fold (0.52 log units) above; the whole stated range lies above it.
By their numbers in this assay, from the lowest: compound 3; then compounds 2 and 1 (each within the scatter of the next).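

Exchanging 4-fluorophenyl for 4-methoxyphenyl gives a 3.0-fold lower number from compound 2 to compound 3 (0.47 log units; beyond the scatter) in this assay and so shows that the group on this aromatic carbon can shift the read-out beyond the scatter. Compound 1 and compound 2 could not show this, as they lie within the scatter of each other and differ in more than one place. Nothing at hand explains the step. From the compounds shown here alone, whether a larger ether such as ethoxy, or an amine, would lower the number further at this position stays open. So does whether methoxy brings a similar step on other versions of the core.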